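A few compounds are considered here, and "the series" means these few. Any claim that something is new, unique, unknown or untested is made for them only; others in the source may bear on it.

Compound 1 `COC(=O)c1ccc(NCc2cncn2Cc2ccc(C)cc2)cc1-c1ccccc1` is measured in a toxicity assay on NIH3T3 cells (Mus musculus) for cytotoxicity, read by resazurin assay (a lower number here means that less compound is needed, a higher number that more compound is needed for the effect), at 50000 nM. Compound 2 `COC(=O)c1ccc(NCc2cncn2Cc2ccc(F)cc2F)cc1-c1ccccc1` gives in this assay a limit of > 1000 nM and no number. Compound 3 `COC(=O)c1ccc(NCc2cncn2Cc2ccc(-c3ccccc3)cc2)cc1-c1ccccc1` likewise gives in this assay only a limit, > 1000 nM, so compound 3 stands at the limit of the measured range. The steps a step that the limit leaves unreadable from compound 1 to compound 2, a step that the limit leaves unreadable from compound 1 to compound 3 and a step that the two limits leave unreadable from compound 2 to compound 3 are all left unreadable in size because of the limit of > 1000 nM in this assay, at which 2 of the 3 values shown sit. Compound 4 `COC(=O)c1ccc(NCc2cncn2Cc2ccccc2Br)cc1-c1ccccc1` differs from compound 3 in one place: 2-bromophenyl in place of 4-phenylphenyl on a saturated chain carbon bound to an aromatic nitrogen. Going by the values given here, no measured step reads out a size for such a change, and an expectation for compound 4 rests on the limits of compound 2 and compound 3 and the value of compound 1. The expected step in this assay is a step that the limit leaves unreadable from compound 3 to compound 4, without a readable direction. Compound 4 is therefore estimated at 20000 nM, between 2000 nM and 100000 nM.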

Compound 4, half-maximal effective concentration: 10000 nM
Compound 4: middle estimate off by 2.0-fold (0.30 log units), on the high side; the range from low to high includes it.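

At the saturated chain carbon bound to an aromatic nitrogen, the change from 4-methylphenyl to 2-bromophenyl gives the first readable size for this position in this assay: a 5.0-fold lower number from compound 1 to compound 4 (0.70 log units; beyond the scatter). The steps from compound 2 and from compound 3 to compound 4 cannot be read, since compound 2 and compound 3 each give only a limit: the limit of > 1000 nM in this assay, at which 2 of the 4 values shown sit.

Going by these compounds, how compound 2 and compound 3 truly rank against compound 1 and compound 4 stays open. Also open, on these data alone, is how an amine or a carboxylic acid in place of 2-bromophenyl at this position would read in this assay.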